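Aminonicotinonitrile series: cyclobutyl amide in place of methoxycyclohexylmethyl

The compounds below may be only part of what the source reports. "The series", "measured", "known", "first", "only" and "open" are said of these compounds alone.

Measured compounds:
- compound 1, `CO[C@H]1CC[C@@H](CNc2cc(NCc3cnccc3C(F)(F)F)ncc2C#N)CC1`: 70 nM
- compound 2, `N#Cc1cnc(NCc2cncnc2C(F)(F)F)cc1N[C@H]1CC[C@@H](O)CC1`: 450 nM

In an assay on isolated protein for inhibition of protein kinase C theta type (Homo sapiens), read by TR-FRET, with a stated time of 2 h (on this read-out lower numbers stand for stronger inhibition and higher numbers for weaker inhibition), compound 1 gives 70 nM and holds the lowest number of the two measured; compound 2 gives 450 nM, a number beyond the scatter above it. Among the measured compounds shown here, compound 2 differs from compound 1 in more than one place, so these two values show only that compound 1 is the stronger inhibitor here.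

Compound 3, `CC1(C)[C@@H](Nc2cc(NCc3cnccc3C(F)(F)F)ncc2C#N)C[C@@H]1C(N)=O`, is unmeasured. It differs from compound 1 by 3-carbamoyl-2,2-dimethylcyclobutyl in place of (4-methoxycyclohexyl)methyl on a nitrogen on an aromatic ring; the amide brings one hydrogen-bond donor where compound 1 has none in that group, and the ring shrinks from six members to four. For the measured compounds named here, no measured pair shows this change, so its size cannot be read from the data. A modest loss, possibly within the scatter, is expected. The step of a 2.1-fold higher number from compound 1 to compound 3 (0.33 log units; beyond the scatter) is the estimate. In this assay compound 3 is expected to give 150 nM, within 40 nM to 600 nM.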

Compound 3, half-maximal inhibitory concentration: 1100 nM
Compound 3: middle estimate off by 7.3-fold (0.87 log units), on the low side; measured number outside the range, above it.
By their numbers in this assay, from the lowest: compound 1; then compound 2; then compound 3.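

On the nitrogen on an aromatic ring, the place is sensitive to the group it carries: in this assay, 3-carbamoyl-2,2-dimethylcyclobutyl in place of (4-methoxycyclohexyl)methyl gives a 16-fold higher number from compound 1 to compound 3 (1.20 log units; beyond the scatter). The two groups have the same count of 9 heavy atoms, so this large step arises without any change in that count, while the ring, the hydrogen-bond donor count and the link to the nitrogen all differ. Nothing available bears on the cause of this loss.

As far as these compounds go, the ring and the carbamoyl group change together, so their separate contributions remain open. A cyclohexyl group carrying the carbamoyl group, or a 2,2-dimethylcyclobutyl group carrying a methoxy group or a carboxylic acid instead, would help to separate them.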